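Working notes on a writhing-test series of four analogues

A few compounds are considered here, and "the series" means these few. Any claim that something is new, unique, unknown or untested is made for them only; others in the source may bear on it.

Measured compounds, with their read-out in a functional assay on the whole organism (strain Kunming) for inhibition, with Mus musculus as the target, in the writhing test, with stated times of 1 h and 15 min, at a dose of 200 mg/kg by the oral route; a lower number here means less inhibition, a higher number more inhibition at the dose given (going by the name of the read-out):
compound 1 `Cc1ccc(N(C)CC2CCC/C(=C\c3ccccc3)C2=O)cc1` gives 81%
compound 2 `Cc1cccc(N(C)CC2CCC/C(=C\c3ccccc3)C2=O)c1` gives 76.7%
compound 3 `COc1ccc(C2(O)/C(=C/c3ccc(C)cc3)CCCC2CN(C)c2ccc(C)cc2)cc1` gives 62.2%

Compound 1 and compound 2 share a core and differ in one place: 3-methylphenyl in place of 4-methylphenyl on an amine nitrogen. In this assay the step is a number 4.3 percentage points lower from compound 1 to compound 2 (within the scatter), so the two values are not separable.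

Compound 3 carries a different core; the difference between the two cores and the core of compound 1 is not broken down here. In this assay compound 3 stands lowest of the three, and its gaps to compound 2 and to compound 1 are both beyond the scatter.

Compound 4 `COc1ccc(C2(O)/C(=C/c3ccc(C)cc3)CCCC2CN(C)c2cccc(C)c2)cc1` is unmeasured. It differs from compound 3 by 3-methylphenyl in place of 4-methylphenyl on an amine nitrogen. The place around the change is the same as between compound 1 and compound 2, so this is the same change applied to the second core.

Among the compounds with values here, only one earlier instance, a number 4.3 percentage points lower from compound 1 to compound 2 (within the scatter), exists. On that basis the step from compound 3 to compound 4 is expected to be a number 4.2 percentage points lower from compound 3 to compound 4 (within the scatter), again within the scatter. Compound 4 is therefore estimated at 58%, with a likely range from 45% to 70%.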

Compound 4, a percentage reported as inhibition, in the whole organism at one dose (the size of the read-out at that dose, not a potency): 74.2%
Compound 4: middle estimate off by 16.2 percentage points, on the low side; measured number above the stated range.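

In this assay, replacing 4-methylphenyl with 3-methylphenyl on the amine nitrogen of the core of compound 3 gives a clear step: a number 12 percentage points higher from compound 3 to compound 4 (beyond the scatter). Within the data shown here, on the core of compound 1 the same change gave no separable difference, so its outcome does not carry from one core to the other: the same change on two cores in this assay, a number 4.3 percentage points lower (within the scatter) from compound 1 to compound 2 and a number 12 percentage points higher (beyond the scatter) from compound 3 to compound 4, 16.3 percentage points apart, beyond the scatter of two such steps This shows that the result of the change depends on the core it sits on, but with only one pair per core and a single oral dose, it does not show which feature of the cores is responsible or predict the outcome on a further core.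

The compounds shown leave open whether a plain phenyl or a 4-chlorophenyl on the same amine nitrogen would show a similar split between the two cores. They also leave open whether the step on the core of compound 3 would persist at another dose in this assay.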